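A Longer Chain on the Shared Core: Compound 3

This account rests on a few compounds, and the source may have more. Where it says the series, first, only, none or still open, it means among the compounds named here.

Within the data shown here, compound 2 `CCCCCCCCOP(=O)(O)OCCSC(=S)N1CCCC1` stands lowest of the two numbers so far in a functional assay on MCF7 cells (Homo sapiens) for inhibition, read by MTT assay, with stated times of 18 h and 4 h (a higher number here means a weaker inhibitor, a lower number a stronger inhibitor), where compound 2 gives 53000 nM. Its nearest neighbour is compound 1 `CCCCCCOP(=O)(O)OCCSC(=S)N1CCCC1`, which in this assay gives 100000 nM; the step of a 1.9-fold lower number from compound 1 to compound 2 (0.28 log units; within the scatter) lies within the scatter, so the two compounds cannot be told apart on these numbers. Compound 3 `CCCCCCCCCCCCCCCCOP(=O)(O)OCCSC(=S)N1CCCC1` differs from compound 2 by octyl in place of hydrogen on a saturated chain carbon, eight bonds along the chain from an oxygen on an unsaturated carbon. Among the measured compounds shown here, the only measured step that bears on this change is a 1.9-fold lower number from compound 1 to compound 2 (0.28 log units; within the scatter), which lengthened the same chain by a smaller piece and produced nothing beyond the scatter. Whether a much longer extension behaves differently is not shown by any measured pair. The step of a 2.1-fold lower number from compound 2 to compound 3 (0.33 log units; beyond the scatter) is therefore expected to be modest, leaning toward a lower number. For compound 3 in this assay the estimate is 25000 nM, with a range from 6000 nM to 90000 nM.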

Compound 3, half-maximal inhibitory concentration: 72000 nM
Beside the measured number, compound 3's estimate is 2.9-fold (0.46 log units) below it; low and high end bracket the measured number.
By their numbers in this assay, from the lowest: compounds 2, 3 and 1 (each within the scatter of the next).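

In this assay, the step of a 1.4-fold higher number from compound 2 to compound 3 (0.13 log units; within the scatter) shows that octyl in place of hydrogen at this chain position, a far larger addition than the ethyl of the earlier step, leaves compound 3 and compound 2 indistinguishable. The step of a 1.4-fold lower number from compound 1 to compound 3 (0.14 log units; within the scatter) says the same for decyl in place of hydrogen, so among the three compounds shown, chain length gives no readable difference on these numbers. Nothing available here offers an explanation for this result.

As far as these compounds go, whether a butyl chain, a branched chain, or a chain carrying an amine or a carboxylic acid would give a number beyond the scatter stays open. The rest of the core is the same in all three compounds, so the effect of a change there is also unknown.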